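Notes on the amide nitrogen substituent: compound 2 to compound 4

A few compounds are considered here, and "the series" means these few. Any claim that something is new, unique, unknown or untested is made for them only; others in the source may bear on it.

Measured compounds:
Compound 1 `O=C(/C=C/c1coc2cc(O)ccc2c1=O)NCc1ccc(F)cc1`: in a functional assay on HeLa cells (Homo sapiens) for inhibition, read by MTT assay, with a stated time of 48 h (on this read-out higher numbers stand for weaker inhibition and lower numbers for stronger inhibition), compound 1 gives > 100000 nM, which is a limit of the assay.
Compound 2 `COc1ccc2c(=O)c(/C=C/C(=O)Nc3ccc(C)cc3)coc2c1`: in this assay compound 2 gives 24100 nM.
Compound 3 `COc1ccc2c(=O)c(/C=C/C(=O)Nc3ccccc3)coc2c1`: in this assay compound 3 gives > 100000 nM, which is a limit of the assay.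

Going by the values given here, compound 2 is the only member with a measured number; the other two stop at a limit. Compound 4 `COc1ccc(CNC(=O)/C=C/c2coc3cc(OC)ccc3c2=O)cc1` is not yet measured. It differs from compound 2 by 4-methoxybenzyl in place of 4-methylphenyl on an amide-type nitrogen.

Among the compounds with values here, the only measured step that touches the group on the amide nitrogen is an at least 4.1-fold higher number from compound 2 to compound 3 (0.61 log units; beyond the scatter), in which removing the methyl alone carried the value to a limit. Compound 1, which differs from compound 2 in more than one place, also sits at a limit; together these give (the limit of > 100000 nM in this assay, at which 2 of the 3 values shown sit). No measured pair isolates the exchange of 4-methylphenyl for 4-methoxybenzyl, so the step for compound 4 is read off the sensitivity shown by the step from compound 2 to compound 3.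

For compound 4 a step toward weaker inhibition of a 2.5-fold higher number from compound 2 to compound 4 (0.40 log units; beyond the scatter) is expected in this assay, with a real chance that only a limit is reported. Compound 4 is estimated at 60000 nM, between 15000 nM and 250000 nM.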

Compound 4, half-maximal inhibitory concentration: > 100000 nM
Compound 4: a limit, no number; the forecaster's own chance of this, stated with the estimate: 45%; at least 1.6-fold (0.22 log units) between middle value and limit.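

Exchanging 4-methylphenyl for 4-methoxybenzyl on the amide-type nitrogen gives an at least 4.1-fold higher number from compound 2 to compound 4 (0.61 log units; beyond the scatter), the second single change at this nitrogen to leave a measured number behind in this assay. From the compounds shown here alone, the step is a lower bound and its true size stays unknown, but with compound 3 it shows that two different exchanges of the group in compound 2 both end at a limit, one removing the methyl and one bringing in a group with a hydrogen-bond acceptor. Compound 2 remains the only member of the series with a number, and the floor of the read-out now dominates the set, while the step from compound 3 to compound 4 cannot be read, as both stop at a limit: the limit of > 100000 nM in this assay, at which 3 of the 4 values shown sit.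

The exchange itself joins two changes, so 4-methylbenzyl or 4-methoxyphenyl on the same nitrogen would be needed to tell the added carbon from the swap of methyl for methoxy. Going by these compounds, whether any group other than 4-methylphenyl keeps a number at this position, such as 4-ethylphenyl or 4-chlorophenyl, also remains open.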